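The source may report more compounds than this note shows. Statements on the series, on what has been measured and on what is new or still open speak of the compounds shown alone.

Compound 3 `CC(C)=CCC1=C(OCc2cn(Cc3ccccc3)nn2)C(=O)c2ccccc2C1=O` is the starting point. In an ADME assay on HepG2 cells (Homo sapiens) for cytotoxicity, read by MTT assay, with a stated time of 24 h (on this read-out lower numbers stand for higher toxicity in this test and higher numbers for lower toxicity in this test), compound 3 gives 414000 nM, the second highest of three numbers: compound 2 `CC(C)=CCC1=C(OCc2cn(C3CCN(C(=O)OC(C)(C)C)CC3)nn2)C(=O)c2ccccc2C1=O` gives 136000 nM, a lower number, while compound 1 `CC(C)=CCC1=C(OCc2cn(-c3ccnc4cc(Cl)ccc34)nn2)C(=O)c2ccccc2C1=O` gives 1940000 nM, the highest. Compound 4 `CC(C)=CCC1=C(OCc2cn(-c3ccccc3)nn2)C(=O)c2ccccc2C1=O` differs from compound 3 in one place: phenyl in place of benzyl on an aromatic nitrogen. Going by the values given here, the one measured step that bears on swapping a ring on the aromatic nitrogen for benzyl is a 4.7-fold lower number from compound 1 to compound 3 (0.67 log units; beyond the scatter); compound 4 carries phenyl there rather than 7-chloroquinolin-4-yl, so that step is only a loose guide. On that basis a modest step toward a higher number is expected: a 1.7-fold higher number from compound 3 to compound 4 (0.23 log units; within the scatter). Compound 4 is estimated at 700000 nM, with a range from 250000 nM to 2000000 nM.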

Compound 4, half-maximal cytotoxic concentration: 100000 nM
Compound 4: middle estimate off by 7.0-fold (0.85 log units), on the high side; measured number below the stated range.
By their numbers in this assay, from the lowest: compounds 4 and 2 (each within the scatter of the next); then compound 3; then compound 1.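

In this assay, a small edit at this position still matters: phenyl in place of benzyl, 6 heavy atoms for 7 with the same carbon ring, gives a 4.1-fold lower number from compound 3 to compound 4 (0.62 log units; beyond the scatter). Phenyl in place of 7-chloroquinolin-4-yl gives a 19-fold lower number from compound 1 to compound 4 (1.29 log units; beyond the scatter), so on this aromatic nitrogen the number spans a wide range, and toxicity in this test is higher with phenyl than with either of those groups. Nothing available explains why the number moves with these groups. Still open, going by these compounds, is whether a longer chain, such as phenylethyl, would carry the number higher than benzyl does, and how an amine on the phenyl ring would shift it.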